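A side-chain swap on a shared core

This account rests on a few compounds, and the source may have more. Where it says the series, first, only, none or still open, it means among the compounds named here.

Compound 1 `Cc1cc(NCCN(C)C)nc2ccc(NC(=O)c3ccc(Cl)c(Cl)c3)cc12`: 6670 nM
Compound 2 `Cc1cc(N2CCN(C(C)C)CC2)nc2ccc(NC(=O)c3ccc(Cl)c(Cl)c3)cc12`: 6680 nM

In a functional assay on SK-BR-3 cells (Homo sapiens) for antiproliferative activity, read by MTT assay, with a stated time of 72 h (on this read-out higher numbers stand for weaker inhibition and lower numbers for stronger inhibition), compound 2 gives 6680 nM, and it cannot be told apart from compound 1 at 6670 nM. The next compound, compound 3 `Cc1cc(NCCN2CCCCC2)nc2ccc(NC(=O)c3ccc(Cl)c(Cl)c3)cc12`, carries (2-(piperidin-1-yl)ethyl)amino in place of 4-isopropylpiperazin-1-yl on an aromatic carbon, next to the ring nitrogen: (2-(piperidin-1-yl)ethyl)amino in place of 4-isopropylpiperazin-1-yl on an aromatic carbon. Among the measured compounds shown here, only one measured step bears on this change. Compound 1 has the related (2-(dimethylamino)ethyl)amino group, and exchanging it for 4-isopropylpiperazin-1-yl gave a 1.0-fold higher number from compound 1 to compound 2 (0.00 log units; within the scatter). For the measured compounds named here, that is a single step, and no measured compound yet shows what the piperidine ring does on such a chain. No change beyond the scatter is therefore expected in this assay, and the estimated step is a 1.3-fold lower number from compound 2 to compound 3 (0.13 log units; within the scatter). The estimate for compound 3 is 5000 nM, with an expected range of 1900 nM to 12000 nM.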

Compound 3, half-maximal inhibitory concentration: 1800 nM
Estimate against measurement, compound 3: 2.8-fold (0.44 log units) above; the measured number lies below the stated range.
By their numbers in this assay, from the lowest: compound 3; then compounds 1 and 2 (each within the scatter of the next).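

The side chain on this aromatic carbon, next to the ring nitrogen, can change the result after all: in this assay, (2-(piperidin-1-yl)ethyl)amino in place of 4-isopropylpiperazin-1-yl gives a 3.7-fold lower number from compound 2 to compound 3 (0.57 log units; beyond the scatter) with the same heavy-atom count. With the chain kept, exchanging only dimethylamino for piperidin-1-yl gives a 3.7-fold lower number from compound 1 to compound 3 (0.57 log units; beyond the scatter) and shows that the ethyl chain alone does not give the lower number; the group at its end counts too. Nothing available here explains why this ring at the chain end goes with the lower number.

Going by these compounds, it remains open whether a pyrrolidine or morpholine ring at the chain end, or a longer chain, would lower the number further. Also open, on these data alone, is whether piperidin-1-yl attached directly to this aromatic carbon, without the chain, would keep the lower number.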